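A few compounds are considered here, and "the series" means these few. Any claim that something is new, unique, unknown or untested is made for them only; others in the source may bear on it.

Three compounds sharing one core have been measured in an assay on HEK293 cells for displacement of a labelled ligand from sodium-dependent dopamine transporter (Homo sapiens), read by scintillation proximity assay; a higher number here means a weaker inhibitor, a lower number a stronger inhibitor:

Compound 1 `c1ccc(CCC2CNCCN2c2ccc3[nH]ncc3c2)cc1`: 31.6 nM
Compound 2 `CC(C)CC1CNCCN1c1ccc2[nH]ncc2c1`: 15.9 nM
Compound 3 `c1cc2[nH]ncc2cc1N1CCNCC1CC1CCCCC1`: 316 nM

Compound 3 gives the highest number of the three, and both of its steps to the others lie beyond the scatter: a 10-fold higher number from compound 1 to compound 3 (1.00 log units; beyond the scatter) and a 20-fold higher number from compound 2 to compound 3 (1.30 log units; beyond the scatter). The next compound, compound 4 `COCCC1CNCCN1c1ccc2[nH]ncc2c1`, is built from compound 3 by one change: methoxymethyl in place of cyclohexyl on a saturated chain carbon bound to a saturated ring carbon.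

The two steps that bear on this change both lead into compound 3. In each, a smaller or flatter group on that saturated chain carbon gave a lower number than cyclohexyl, and the isopropyl case gave the lowest of all. Among the compounds with values here, compound 4 again trades the cyclohexyl for a smaller group, so a step downward in this assay is expected, though no measured compound carries an oxygen in this chain, which keeps the estimate uncertain. For compound 4 the step is estimated as a 5.3-fold lower number from compound 3 to compound 4 (0.72 log units; beyond the scatter). Compound 4 is therefore expected to give about 60 nM, most likely between 12 nM and 300 nM.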

Compound 4, inhibition constant: 158 nM
For compound 4 the middle estimate is 2.6-fold (0.42 log units) below the measured one; measured number inside the range.
By their numbers in this assay, from the lowest: compounds 2 and 1 (each within the scatter of the next); then compounds 4 and 3 (each within the scatter of the next).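

In this assay, replacing cyclohexyl with methoxymethyl, which has fewer heavy atoms, no ring and one hydrogen-bond acceptor, gives a 2.0-fold lower number from compound 3 to compound 4 (0.30 log units; within the scatter) and so does not separate these two compounds. This oxygen-bearing chain therefore shows that removing the ring and shortening the group is not enough on its own to reach the low numbers seen with the other groups at this position. Compound 4 remains clearly apart from both of those compounds, with a 9.9-fold higher number from compound 2 to compound 4 (1.00 log units; beyond the scatter) and a 5.0-fold higher number from compound 1 to compound 4 (0.70 log units; beyond the scatter) on the same scale, and here the oxygen-containing chain stands with cyclohexyl rather than with isopropyl or benzyl.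

Still open, on these data alone, is how a hydroxyl group, an amine or a longer ether chain would behave on this saturated chain carbon. No measurement shown gives a reason for any of these steps.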